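This account rests on a few compounds, and the source may have more. Where it says the series, first, only, none or still open, it means among the compounds named here.

Series in a functional assay on K562 cells (Homo sapiens) for inhibition, read by trypan blue exclusion, with a stated time of 72 h; a higher number here means a weaker inhibitor, a lower number a stronger inhibitor:
- compound 1 `Cn1c(=O)c(S(=O)(=O)Cc2ccc(F)cc2F)cc2cnc(Nc3ccc4[nH]ccc4c3)nc21`: 1000 nM
- compound 2 `Cn1c(=O)c(S(=O)(=O)c2ccc(Cl)cc2)cc2cnc(Nc3ccc4[nH]ccc4c3)nc21`: 100 nM
- compound 3 `Cn1c(=O)c(S(=O)(=O)c2ccc(Cl)cc2)cc2cnc(Nc3cccc4[nH]ccc34)nc21`: 5000 nM

Of these three, compound 2 has the lowest number, 100 nM. Compound 4 `Cn1c(=O)c(S(=O)(=O)c2ccc(N)cc2F)cc2cnc(Nc3ccc4[nH]ccc4c3)nc21` differs from it as follows: 4-amino-2-fluorophenyl in place of 4-chlorophenyl on a sulfonyl sulfur. This places 4-amino-2-fluorophenyl in place of 4-chlorophenyl on a sulfonyl sulfur.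

Going by the values given here, the one measured change at a sulfonyl sulfur is a 10-fold lower number from compound 1 to compound 2 (1.00 log units; beyond the scatter). That step is modest, and it involves a different pair of groups. The large step, a 50-fold higher number from compound 2 to compound 3 (1.70 log units; beyond the scatter), lies on a nitrogen on an aromatic ring and does not bear on this change. Among the compounds with values here, no measured step compares two aryl groups on the sulfonyl sulfur, so the direction is open and nothing beyond the scatter is expected in this assay. The expected step is a 1.3-fold lower number from compound 2 to compound 4 (0.10 log units; within the scatter). Compound 4 is estimated at 80 nM, with an expected range of 15 nM to 450 nM.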

Compound 4, half-maximal inhibitory concentration: 1500 nM
Compound 4: middle estimate off by 19-fold (1.27 log units), on the low side; measured number above the stated range.
By their numbers in this assay, from the lowest: compound 2; then compounds 1 and 4 (each within the scatter of the next); then compound 3.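

In this assay, the aryl group on the sulfonyl sulfur matters: 4-amino-2-fluorophenyl in place of 4-chlorophenyl gives a 15-fold higher number from compound 2 to compound 4 (1.18 log units; beyond the scatter) and so costs activity. With a 1.5-fold higher number from compound 1 to compound 4 (0.18 log units; within the scatter) as well, 4-amino-2-fluorophenyl and 2,4-difluorobenzyl cannot be told apart, leaving 4-chlorophenyl alone ahead of both at this position. Nothing measured here explains the loss.

The amino group and the fluorine enter together, so the step cannot be assigned to either one. On these data alone, how 4-aminophenyl, 2-fluorophenyl or 4-methoxyphenyl on the sulfonyl sulfur would read remains open.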